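A few compounds are considered here, and "the series" means these few. Any claim that something is new, unique, unknown or untested is made for them only; others in the source may bear on it.

Compound 2 `O=C(O)CCc1ccc(C#Cc2cccnc2)cc1` is a phenylpropanoic acid whose alkyne carries a pyridine ring; in an in vitro functional assay on 1321-N1 cells for agonist activity at Free fatty acid receptor 1 (Homo sapiens), read by fluorescence, spectrophotometry and calcium flux (a higher number here means a larger maximal response, a lower number a smaller maximal response), compound 2 reaches 96%. Compound 1 `O=C(O)C1CC1c1ccc(C#Cc2cc(Cl)nc(Cl)c2)cc1`, built on a cyclopropane acid, gives 96% in this assay, so compound 2 stands level with it at the digits shown, the pair together the highest of the three numbers. Compound 3 `O=C(O)CCc1ccc(C#Cc2cccnc2Cl)cc1`, in which a chlorine sits on that pyridine, gives 91%.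

Compound 4 `O=C(O)CCc1ccc(C#Cc2ccc(Cl)nc2)cc1` differs from compound 2 by chloro in place of hydrogen on an aromatic carbon. For the measured compounds named here, the one step that bears on it is the same kind of change, a number 5 percentage points lower from compound 2 to compound 3 (within the scatter), a shift within the scatter. For compound 4 the expected step is therefore a number 3 percentage points lower from compound 2 to compound 4 (within the scatter), no real change. Compound 4 is estimated at 93%, between 83% and 100%.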

Compound 4, largest response reached (reported as efficacy), in percent of the reference or control that the assay uses: 98%
Compound 4: the middle estimate sits 5 percentage points below what was measured; the measured number falls inside the stated range.
By their numbers in this assay, from the lowest: compounds 3, 1, 2 and 4 (each within the scatter of the next).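

Chloro on the aromatic carbon next to the ring nitrogen and para to a large group leaves the maximal response in this assay within the scatter (a number 2 percentage points higher from compound 2 to compound 4 (within the scatter)). Together with the earlier step (a number 5 percentage points lower from compound 2 to compound 3 (within the scatter)), this shows that the pyridine carries chloro at a second place with no change beyond the scatter. No measurement available here explains this result. Going by these compounds, whether an amine or a methoxy group at this same place would also hold the response remains open, and so does whether a larger group such as phenyl would.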